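A few compounds are considered here, and "the series" means these few. Any claim that something is new, unique, unknown or untested is made for them only; others in the source may bear on it.

Three members of the series share one core and differ only in the group on the sulfonamide nitrogen. Compound 1 `C=C1CC[C@@H]2[C@](C)(COC(C)=O)[C@H](OC(C)=O)CC[C@@]2(C)[C@H]1CC(Nc1ccc(S(=O)(=O)Nc2ccc(Cl)nn2)cc1)C1=CCOC1=O` gives 780 nM in a functional assay on MCF7 cells (Homo sapiens) for inhibition, read by sulforhodamine B assay, with a stated time of 48 h; on this read-out lower numbers stand for stronger inhibition of growth and higher numbers for weaker inhibition of growth. Compound 2 `C=C1CC[C@@H]2[C@](C)(COC(C)=O)[C@H](OC(C)=O)CC[C@@]2(C)[C@H]1CC(Nc1ccc(S(=O)(=O)Nc2cc(C)on2)cc1)C1=CCOC1=O` gives 590 nM in this assay, and compound 3 `C=C1CC[C@@H]2[C@](C)(COC(C)=O)[C@H](OC(C)=O)CC[C@@]2(C)[C@H]1CC(Nc1ccc(S(=O)(=O)Nc2ncccn2)cc1)C1=CCOC1=O` gives 1070 nM in the same assay. Compound 2 holds the smallest number of the three, yet both other compounds sit within the scatter of it: a 1.3-fold lower number from compound 1 to compound 2 (0.12 log units; within the scatter) and a 1.8-fold higher number from compound 2 to compound 3 (0.26 log units; within the scatter). The remaining pair reads a 1.4-fold higher number from compound 1 to compound 3 (0.14 log units; within the scatter), again within the scatter. Compound 4 `C=C1CC[C@@H]2[C@](C)(COC(C)=O)[C@H](OC(C)=O)CC[C@@]2(C)[C@H]1CC(Nc1ccc(S(=O)(=O)Nc2nccs2)cc1)C1=CCOC1=O` has not yet been measured; it differs from compound 2 by 1,3-thiazol-2-yl in place of 5-methyl-1,2-oxazol-3-yl on a sulfonamide nitrogen. The measured steps bearing on this change are the three exchanges of the group on the sulfonamide nitrogen, none of which moved the number beyond the scatter, so no step beyond the scatter is expected in this assay, with a 1.2-fold higher number from compound 2 to compound 4 (0.06 log units; within the scatter) as the working expectation. Compound 4 is accordingly estimated at 680 nM, with a range from 350 nM to 1350 nM.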

Compound 4, concentration for 50% growth inhibition: 2590 nM
Beside the measured number, compound 4's estimate is 3.8-fold (0.58 log units) below it, outside the stated range (above it).
By their numbers in this assay, from the lowest: compounds 2, 1 and 3 (each within the scatter of the next); then compound 4.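

Among these compounds, the group on the sulfonamide nitrogen is not a silent position in this assay: 1,3-thiazol-2-yl gives the first exchange in this set to pass the scatter, with a 4.4-fold higher number from compound 2 to compound 4 (0.64 log units; beyond the scatter) and also a 3.3-fold higher number from compound 1 to compound 4 (0.52 log units; beyond the scatter) and a 2.4-fold higher number from compound 3 to compound 4 (0.38 log units; beyond the scatter) as modest steps towards weaker inhibition of growth. The tolerance seen among 5-methyl-1,2-oxazol-3-yl, 6-chloropyridazin-3-yl and pyrimidin-2-yl therefore does not extend to 1,3-thiazol-2-yl, even though it matches 5-methyl-1,2-oxazol-3-yl in ring size and in hydrogen-bond donor and acceptor counts. No measurement at hand gives a reason for these steps.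

The compounds shown do not separate the ring sulfur from the absent methyl as the source of the step from 5-methyl-1,2-oxazol-3-yl. Going by these compounds, how a plain phenyl, a pyridin-2-yl or a bare hydrogen on the sulfonamide nitrogen would read in this assay also stays open.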